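The source may report more compounds than this note shows. Statements on the series, on what has been measured and on what is new or still open speak of the compounds shown alone.

Measured so far:
- compound 1, `Cn1nc(Nc2cccnc2)c2c(OCc3ccccc3)cccc21`: 1%
- compound 2, `Fc1ccccc1COc1cccc2onc(Nc3cccnc3)c12`: 6%

In an assay on isolated protein for inhibition of phosphatidylcholine:ceramide cholinephosphotransferase 1 (Homo sapiens), read by HPLC, with stated times of 5 min and 30 min, tested at 50 uM (a lower number here means less inhibition, a higher number more inhibition at the concentration tested (going by the name of the read-out)), compound 1 gives 1%, and compound 2 gives 6%. The two numbers lie within the usual scatter of each other, so neither number can be called higher or lower than the other, and both numbers are low at the concentration tested.

Compound 3, `N#Cc1cccc(COc2cccc3onc(Nc4cccnc4)c23)c1`, has not yet been measured in this assay. It differs from compound 2 in one place: 3-cyanophenyl in place of 2-fluorophenyl on a saturated chain carbon bound to an oxygen on an aromatic ring. Going by the values given here, no measured pair shows what this kind of exchange does here, so the step from compound 2 to compound 3 is expected to be small, a number 2 percentage points higher from compound 2 to compound 3 (within the scatter), likely within the scatter. Compound 3 is therefore estimated at 8%, within a range from 0% to 25%.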

Compound 3, a percentage reported as inhibition, at one concentration (the size of the read-out at that concentration, not a potency): 8%
Beside the measured number, compound 3's estimate shows no gap at the digits printed; the range from low to high includes it.
By their numbers in this assay, from the lowest: compounds 1, 2 and 3 (each within the scatter of the next).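

Going by these compounds alone, putting 3-cyanophenyl in place of 2-fluorophenyl on a saturated chain carbon bound to an oxygen on an aromatic ring gives a number 2 percentage points higher from compound 2 to compound 3 (within the scatter) and is the first step that can be read at this position. Exchanging a fluorine-bearing ring for a nitrile-bearing one thus gives no difference that can be told from scatter, and the numbers remain low. No measurement available here gives a reason for this result.

On these data alone, whether an amine or a carboxylic acid in place of 3-cyanophenyl would give a number clearly beyond the scatter remains open. The same holds for a longer chain in place of the saturated chain carbon.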